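A few compounds are considered here, and "the series" means these few. Any claim that something is new, unique, unknown or untested is made for them only; others in the source may bear on it.

Within the data shown here, in a functional assay on MDA-MB-231 cells (Homo sapiens) for cytotoxicity, read by MTT assay, with a stated time of 38 h (a lower number here means a stronger inhibitor, a higher number a weaker inhibitor), compound 1 (`COc1cc(OC)c2c(=O)c(OCC(=O)N/N=C/c3ccccc3F)c(-c3cc(OC)c(OC)c(OC)c3)oc2c1`) gives 3400 nM and compound 2 (`COc1cc(OC)c2c(=O)c(OCCCCN3CCCCC3)c(-c3cc(OC)c(OC)c(OC)c3)oc2c1`) gives 3030 nM, so compound 2 sits within the scatter of the only other measured compound. Compound 3 (`CCN(CC)CCCCOc1c(-c2cc(OC)c(OC)c(OC)c2)oc2cc(OC)cc(OC)c2c1=O`) differs from compound 2 as follows: diethylamino in place of piperidin-1-yl on a saturated chain carbon, four bonds along the chain from an oxygen on an aromatic ring. Among the measured compounds shown here, the one measured step, a 1.1-fold lower number from compound 1 to compound 2 (0.05 log units; within the scatter), replaced a larger group on the chain and stayed within the scatter. It is a single step, so it offers only weak guidance, and no shift in either direction is expected. The estimated step is a 1.0-fold lower number from compound 2 to compound 3 (0.00 log units; within the scatter), which is none beyond the scatter. Compound 3 is expected at 3000 nM, with an estimated range of 1400 nM to 6500 nM.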

Compound 3, half-maximal inhibitory concentration: 13000 nM
The estimate for compound 3 lay 4.3-fold (0.64 log units) below the measured number, and the stated range ends below it.
By their numbers in this assay, from the lowest: compounds 2 and 1 (each within the scatter of the next); then compound 3.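

In this assay, the amine at the end of the chain proves to matter at this position: diethylamino in place of piperidin-1-yl gives a 4.3-fold higher number from compound 2 to compound 3 (0.63 log units; beyond the scatter) on an unchanged chain. The replacement of the larger group of compound 1 by this open-chain amine also gives a 3.8-fold higher number from compound 1 to compound 3 (0.58 log units; beyond the scatter), whereas the earlier step stayed within the scatter. Nothing available accounts for this shift. Going by these compounds, it remains open whether any ring at the chain end would match piperidin-1-yl. Pyrrolidin-1-yl, morpholin-4-yl or a shorter chain carrying piperidin-1-yl could each behave differently.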